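The source may hold more compounds than are shown below. What is called first, only, known or untested is meant among the compounds shown, and "the series" means these compounds.

Compound 1 `CC(=O)N[C@@H](CSC/C=C(\C)CC/C=C(\C)CCC=C(C)C)C(=O)C=[N+]=[N-]` gives 32200 nM in a functional assay on MOLT-3 cells (Homo sapiens); on this read-out higher numbers stand for weaker inhibition and lower numbers for stronger inhibition. Compound 2 `CC(C)=CCC/C(C)=C/CC/C(C)=C/CSC[C@H](NC(=O)OC(C)(C)C)C(=O)C=[N+]=[N-]` differs from it by one change, (tert-butoxy in place of methyl on a carbonyl carbon), and in this assay compound 2 gives 50100 nM, a step of a 1.6-fold higher number from compound 1 to compound 2 (0.19 log units; within the scatter). Compound 3 `CCCCCCCCCCCCSC[C@H](NC(C)=O)C(=O)CCl` belongs to a different core; the difference between the two cores is not broken down here. In this assay compound 3 gives 2300 nM, the lowest of the three numbers. Compound 4 `CCCCCCCCCCCCSC[C@H](NC(=O)OC(C)(C)C)C(=O)CCl` carries the same change on the core of compound 3: tert-butoxy in place of methyl on a carbonyl carbon. Since the same change left the number for compound 2 within the scatter of compound 1 after a 1.6-fold higher number from compound 1 to compound 2 (0.19 log units; within the scatter), the step from compound 3 to compound 4 is expected to be about as small, a 1.5-fold higher number from compound 3 to compound 4 (0.18 log units; within the scatter). On that basis compound 4 is estimated at 3500 nM, between 1500 nM and 9000 nM.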

Compound 4, half-maximal inhibitory concentration: 15500 nM
Beside the measured number, compound 4's estimate is 4.4-fold (0.65 log units) below it, outside the stated range (above it).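

On the core of compound 3, tert-butoxy in place of methyl on a carbonyl carbon gave a 6.7-fold higher number from compound 3 to compound 4 (0.83 log units; beyond the scatter) in this assay. The change therefore did not carry over at the same size from one core to the other: the same change on two cores in this assay, a 1.6-fold higher number (0.19 log units; within the scatter) from compound 1 to compound 2 and a 6.7-fold higher number (0.83 log units; beyond the scatter) from compound 3 to compound 4, 4.3-fold (0.64 log units) apart, beyond the scatter of two such steps. These two pairs show only that the size of the step depends on the core; the cores differ in more than one place, and the pairs do not tell which difference goes with the gap, nor do they give a rule for other cores. The compounds shown leave open where ethoxy or benzyloxy in place of methyl on this carbonyl carbon would fall on either core. They also leave open whether the free amine would follow the same course.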